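The source may hold more compounds than are shown below. What is called first, only, known or untested is meant among the compounds shown, and "the series" means these compounds.

Measured compounds:

Compound 1, `COc1cc(-c2cccc3nc(-c4ccccc4)oc23)cc(OC)c1OC`: 20300 nM
Compound 2, `COc1ccc(-c2nc3cccc(-c4cc(OC)c(OC)c(OC)c4)c3o2)cc1F`: 1800 nM
Compound 3, `COc1cc(-c2cccc3nc(-c4ccc(F)cc4)oc23)cc(OC)c1OC`: 8700 nM

These three compounds share one core and differ only in the ring that hangs from it. In a functional assay on A549 cells (Homo sapiens) for antiproliferative activity, read by MTT assay, with a stated time of 48 h (a lower number here means a stronger inhibitor, a higher number a weaker inhibitor), compound 3 gives 8700 nM and stands second highest of the three numbers; its nearest neighbour is compound 1, the step of a 2.3-fold lower number from compound 1 to compound 3 (0.37 log units; beyond the scatter), and its furthest is compound 2, the step of a 4.8-fold higher number from compound 2 to compound 3 (0.68 log units; beyond the scatter).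

Compound 4, `COc1cc(-c2cccc3nc(-c4ccc(Br)cc4)oc23)cc(OC)c1OC`, has not yet been measured. The change from compound 3 to compound 4 is bromo in place of fluoro on an aromatic carbon.

Within the data shown here, no measured step swaps one halogen for another. The step that bears most on it is the addition of fluoro on that same ring, a 2.3-fold lower number from compound 1 to compound 3 (0.37 log units; beyond the scatter), which was modest. The large step of an 11-fold lower number from compound 1 to compound 2 (1.05 log units; beyond the scatter) introduced two groups at once and so says little about a single halogen swap. Bromo is a heavier atom than fluoro, but nothing measured here shows how that matters. A modest lowering of the number, or no step beyond the scatter, is therefore expected for compound 4, given as a 1.5-fold lower number from compound 3 to compound 4 (0.16 log units; within the scatter).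

Compound 4 is estimated at 6000 nM in this assay, with a likely range of 2500 nM to 15000 nM.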

Compound 4, half-maximal inhibitory concentration: > 25000 nM
Compound 4: no number, only a limit; the forecaster's own chance of this, stated with the estimate: 5%; at least 4.1-fold (0.61 log units) between middle value and limit.
By their numbers in this assay, from the lowest: compound 2; then compound 3; then compound 1. At a limit, above all of these: compound 4.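

Among these compounds, at this place on the ring, para to a large group, the earlier compounds showed only that adding fluoro lowers the number in this assay, and the new result shows that this gain does not carry over to every halogen: an at least 2.8-fold higher number from compound 3 to compound 4 (0.45 log units; beyond the scatter). Measured against the compound with hydrogen at this place, bromo gives an at least 1.2-fold higher number from compound 1 to compound 4 (0.09 log units; that floor lies within the scatter), so compound 4 cannot be said to differ from compound 1, whereas the ring carrying both fluoro and methoxy stays far ahead, with an at least 13-fold higher number from compound 2 to compound 4 (1.14 log units; beyond the scatter). Compound 4 has only a limit of the assay and not a number, and so each of these steps is a minimum, with compound 4 alone at that limit: the limit of > 25000 nM in this assay, at which 1 of the 4 values shown sits.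

The compounds shown leave open where a chloro group would fall relative to fluoro and bromo, and how far the true value of compound 4 lies past its limit. They also do not separate the contributions of the fluoro and the methoxy on the ring of compound 2, so a lone methoxy or an amine at this place remains an open comparison.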